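This account rests on a few compounds, and the source may have more. Where it says the series, first, only, none or still open, it means among the compounds named here.

Measured so far:
- compound 1 `CCS(=O)(=O)N[C@@H]1CCCc2c1cncc2N1Cc2cc(Cl)ccc2C1=O` — 1790 nM
- compound 2 `O=C1c2ccc(Cl)cc2C(C2CC2)N1c1cccnc1` — 32500 nM
- compound 3 `CCC(=O)N[C@@H]1CCCc2c1cncc2N1C(=O)c2ccc(Cl)cc2[C@H]1C` — 9410 nM

All three values come from an ADME assay on cells for inhibition of cytochrome P450 11B1, mitochondrial (Homo sapiens), read by HTRF; on this read-out higher numbers stand for weaker inhibition and lower numbers for stronger inhibition. On these numbers compound 1 stands lowest: compound 3 sits nearest to it with a higher number, and compound 2 lies furthest away with the highest number of the three, both gaps beyond the scatter. Among the measured compounds shown here, neither of those pairs differs from compound 1 in a single place, so no step is drawn between them.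

Compound 4 `CS(=O)(=O)N[C@@H]1CCCc2c1cncc2N1Cc2cc(Cl)ccc2C1=O` differs from compound 1 by one change only: hydrogen in place of methyl on a saturated chain carbon bound to a sulfonyl sulfur. For the measured compounds named here, no measured pair shows this change, so the step in this assay can only be estimated from the size of the change. The step from compound 1 to compound 4 is expected to be small, a 1.2-fold higher number from compound 1 to compound 4 (0.09 log units; within the scatter), not beyond the scatter in either direction. Compound 4 is therefore estimated at 2200 nM, in the range 900 nM to 5500 nM.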

Compound 4, half-maximal inhibitory concentration: 9350 nM
Compound 4: the middle estimate sits 4.3-fold (0.63 log units) below what was measured, and the stated range ends below it.
By their numbers in this assay, from the lowest: compound 1; then compounds 4 and 3 (each within the scatter of the next); then compound 2.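

The end of the sulfonyl chain is not silent in this assay: going from ethylsulfonyl to methylsulfonyl gives a 5.2-fold higher number from compound 1 to compound 4 (0.72 log units; beyond the scatter), a modest step but beyond the scatter. Among the compounds shown here, this is the first single-place comparison, and it shows that the loss of one methyl on a saturated chain carbon bound to a sulfonyl sulfur is enough to move this read-out, with ethyl giving the lower number of the pair. No measurement at hand bears on the origin of this step.

The compounds shown leave open whether a longer chain such as propyl, or a cyclopropyl group, on the sulfonyl sulfur would extend this direction or reverse it. For the compounds shown here, with only two chain lengths compared, they also leave open how far the trend runs.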